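Trimming the Hydroxylated Side Chain to Ethyl

The compounds below may be only part of what the source reports. "The series", "measured", "known", "first", "only" and "open" are said of these compounds alone.

Of the compounds shown here, three on a shared core have been tested in an assay on isolated protein for inhibition of protein kinase C epsilon type (Homo sapiens), read by coupled enzyme assay; a lower number here means a stronger inhibitor, a higher number a weaker inhibitor. Compound 1 `C[C@H](O)Cc1cc(-c2ccnc3[nH]nc(C(F)(F)F)c23)cc(C2(C#N)CC2)c1` gives 51 nM. Compound 2 `N#CC1(c2cc(CC(O)C(F)(F)F)cc(-c3ccnc4[nH]nc(C(F)(F)F)c34)c2)CC1` gives 267 nM. Compound 3 `COCC(O)Cc1cc(-c2ccnc3[nH]nc(C(F)(F)F)c23)cc(C2(C#N)CC2)c1` gives 77 nM, which places compound 3 second highest of the three numbers, close to compound 1 and well apart from compound 2. The step of a 1.5-fold higher number from compound 1 to compound 3 (0.18 log units; within the scatter) lies within the scatter, whereas a 5.2-fold higher number from compound 1 to compound 2 (0.72 log units; beyond the scatter) and a 3.5-fold lower number from compound 2 to compound 3 (0.54 log units; beyond the scatter) are modest steps beyond it.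

Compound 4 `CCc1cc(-c2ccnc3[nH]nc(C(F)(F)F)c23)cc(C2(C#N)CC2)c1` differs from compound 3 by methyl in place of 1-hydroxy-2-methoxyethyl on a saturated chain carbon bound to an aromatic carbon. For the measured compounds named here, none of the measured steps removes the hydroxyl group itself; they only vary what sits beside it, and the two hydroxylated analogues compound 1 and compound 3 sit together while compound 2 lies apart. The measured steps therefore bear only loosely on this change. With the hydroxyl and methoxy groups both gone, a modest rise in this assay is expected, a 2.1-fold higher number from compound 3 to compound 4 (0.32 log units; beyond the scatter). Compound 4 is estimated at 160 nM, with a range from 50 nM to 500 nM.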

Compound 4, inhibition constant: 78 nM
For compound 4 the middle estimate is 2.1-fold (0.31 log units) above the measured one, and the stated range covers the measured number.
By their numbers in this assay, from the lowest: compounds 1, 3 and 4 (each within the scatter of the next); then compound 2.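

In this assay, the position tolerates complete loss of the hydroxylated side chain: on going to ethyl, the number stays within the scatter by both routes, a 1.0-fold higher number from compound 3 to compound 4 (0.01 log units; within the scatter) and a 1.5-fold higher number from compound 1 to compound 4 (0.18 log units; within the scatter). The one clear separation involving the new compound is a 3.4-fold lower number from compound 2 to compound 4 (0.53 log units; beyond the scatter), so among these four compounds the gap at this position goes with the 2,2,2-trifluoro-1-hydroxyethyl group of compound 2, not with the absence of a hydroxyl. No independent evidence bears on why the numbers fall this way.

The compounds shown leave open how an amine or a carboxylic acid would behave on this saturated chain carbon. They also leave open whether a longer unsubstituted chain, such as propyl or butyl, would keep the number of compound 4.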